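The source may hold more compounds than are shown below. What is called first, only, known or untested is meant among the compounds shown, and "the series" means these compounds.

Measured compounds, all in an ADME assay on Raji cells (Homo sapiens) for cytotoxicity, read by CellTiter-Glo and resazurin assay, with a stated time of 72 h; a lower number here means that less compound is needed, a higher number that more compound is needed for the effect:

Compound 1 `CC(C)N(Cc1cccc(OCCCCCC(=O)O)c1)C(=O)c1ccc(-c2cccc(N(C)C)c2)cc1`. In this assay compound 1 gives > 26000 nM, a limit of the assay and not a number.
Compound 2 `CC(C)N(Cc1cccc(OCCCCCC(=O)O)c1)C(=O)c1ccc(-c2ccco2)cc1`. In this assay compound 2 gives > 26000 nM, likewise a limit.
Compound 3 `CCOC(=O)CCCCCOc1cccc(CN(C(=O)c2ccc(-c3ccco3)cc2)C(C)C)c1`. In this assay compound 3 gives > 26000 nM, again a limit.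

Compound 3 thus stands where all three values sit, at the limit of > 26000 nM in this assay, at which 3 of the 3 values shown sit. The two measured steps, a step that the two limits leave unreadable from compound 1 to compound 2 and a step that the two limits leave unreadable from compound 2 to compound 3, are both unreadable, since each joins two limits, so neither bears a size on the next change.

Compound 4 `CCOC(=O)CCCCCOc1cccc(CN(C(=O)c2ccc(-c3ccc(Cl)c(Cl)c3)cc2)C(C)C)c1` differs from compound 3 by 3,4-dichlorophenyl in place of furan-2-yl on an aromatic carbon. Among the compounds with values here, no measured step covers this exchange, and the nearest one, the change of the aryl group on the same carbon, is itself unreadable. The expected step that the limit leaves unreadable from compound 3 to compound 4 is therefore set at none beyond the scatter, with the series giving no reason to expect compound 4 to leave the region of the limit. Compound 4 is estimated at 30000 nM, in the range 8000 nM to 100000 nM, with a limit as the most likely report.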

Compound 4, half-maximal effective concentration: > 26000 nM
Compound 4: a limit, no number; the forecaster's own chance of this, stated with the estimate: 70%; the middle value lies beyond the limit too.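

In this assay, within the data shown here, compound 4 gives > 26000 nM, a limit of the assay and not a number; with compound 3 also at a limit, no step between them can be read. The compounds shown leave open whether any change moves a value off this limit.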